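The compounds below may be only part of what the source reports. "The series", "measured", "known", "first", "only" and "open" are said of these compounds alone.

Compound 1 `O=C(Nc1ccc(F)cc1F)c1cncc(N2CC3CC(C2)N3)c1` has the lowest number among the three measured compounds in an assay on cells for displacement of a labelled ligand from Neuronal acetylcholine receptor; alpha3/beta4 (Homo sapiens) (on this read-out higher numbers stand for weaker inhibition and lower numbers for stronger inhibition), where compound 1 gives 50 nM. Compound 2 `O=C(Nc1ccc(F)cc1)c1cncc(N2CC3CC(C2)N3)c1` gives 81 nM in this assay, and compound 3 `O=C(NCc1ccccc1)c1cncc(N2CC3CC(C2)N3)c1` gives 1600 nM. Compound 4 `CCc1cccc(NC(=O)c2cncc(N3CC4CC(C3)N4)c2)c1` has not yet been measured; it differs from compound 1 as follows: 3-ethylphenyl in place of 2,4-difluorophenyl on an amide-type nitrogen. The step of a 1.6-fold higher number from compound 1 to compound 2 (0.21 log units; within the scatter) shows that hydrogen in place of fluoro changed little. The steps of a 32-fold higher number from compound 1 to compound 3 (1.51 log units; beyond the scatter) and a 20-fold higher number from compound 2 to compound 3 (1.30 log units; beyond the scatter) show a large loss when benzyl replaces an aromatic group, but compound 4 keeps an aromatic group on the amide-type nitrogen, so only a modest weakening, or none beyond the scatter, is expected. Compound 4 is estimated at 110 nM, between 35 nM and 400 nM, which is expected to mean a 2.2-fold higher number from compound 1 to compound 4 (0.34 log units; beyond the scatter).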

Compound 4, inhibition constant: 306 nM
Beside the measured number, compound 4's estimate is 2.8-fold (0.44 log units) below it; measured number inside the range.
By their numbers in this assay, from the lowest: compounds 1 and 2 (each within the scatter of the next); then compound 4; then compound 3.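

In this assay the change to 3-ethylphenyl on an amide-type nitrogen gives a 6.1-fold higher number from compound 1 to compound 4 (0.79 log units; beyond the scatter) and a 3.8-fold higher number from compound 2 to compound 4 (0.58 log units; beyond the scatter) so an aromatic ring at this place does not alone keep the number low, and what the ring carries also counts. Set against benzyl, 3-ethylphenyl still shows a 5.2-fold lower number from compound 3 to compound 4 (0.72 log units; beyond the scatter) in these compounds. No measurement shown here accounts for these differences.

From the compounds shown here alone, whether the ethyl group itself or its place on the ring sets the rise stays open. So does how a phenyl ring carrying an amine, a carboxylic acid or a longer chain would read.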